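The source may hold more compounds than are shown below. What is called first, only, known or untested is meant among the compounds shown, and "the series" means these compounds.

In a functional assay on A549 cells (Homo sapiens) for antiproliferative activity, with a stated time of 5 days (on this read-out higher numbers stand for weaker inhibition and lower numbers for stronger inhibition), compound 1 `COc1ccc(-n2nc(-c3ccc4ccccc4c3)nc2N2C(=O)COC23C=CC(=O)C=C3)cc1` gives 260 nM and compound 3 `Cc1ccccc1-n1nc(-c2cccc3ccccc23)nc1N1C(=O)COC12C=CC(=O)C=C2` gives 130 nM, two values within the scatter of each other. Compound 3 lies clearly under compound 2 `COc1ccc(-n2nc(-c3ccc4ccccc4c3)nc2N2C(=O)C(C)OC23C=CC(=O)C=C3)cc1`, which gives 860 nM. Compound 4 `O=C1C=CC2(C=C1)OCC(=O)N2c1nc(-c2cccc3ccccc23)nn1-c1ccccc1` has not yet been measured. It departs from compound 3 by hydrogen in place of methyl on an aromatic carbon, with hydrogen in place of methyl on an aromatic carbon, ortho to a large group. Going by the values given here, the only measured step, a 3.3-fold higher number from compound 1 to compound 2 (0.52 log units; beyond the scatter), also exchanges methyl and hydrogen, but on a saturated ring carbon, so it is a weak guide here. Among the compounds with values here, no measured pair tests the aromatic methyl itself. No change beyond the scatter is therefore expected in this assay, and the estimated step is a 1.4-fold higher number from compound 3 to compound 4 (0.14 log units; within the scatter). Compound 4 is estimated at 180 nM, with an expected range from 70 nM to 450 nM.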

Compound 4, half-maximal inhibitory concentration: 80 nM
The estimate for compound 4 lay 2.3-fold (0.35 log units) above the measured number; measured number inside the range.
By their numbers in this assay, from the lowest: compounds 4, 3 and 1 (each within the scatter of the next, the first and the last beyond it); then compound 2.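

The change from 2-methylphenyl to phenyl gives a 1.6-fold lower number from compound 3 to compound 4 (0.21 log units; within the scatter) in this assay, the first direct test of a methyl on this aromatic carbon. Unlike the methyl on the saturated ring carbon, which gave a 3.3-fold higher number from compound 1 to compound 2 (0.52 log units; beyond the scatter), this methyl is not needed to keep the activity of compound 3. No measurement shown here accounts for this result.

As far as these compounds go, it remains open how an amine or a carboxylic acid on this aromatic carbon would read in this assay. The compounds also leave open whether a longer chain would be accepted there.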